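A few compounds are considered here, and "the series" means these few. Any claim that something is new, unique, unknown or untested is made for them only; others in the source may bear on it.

Measured so far:
- compound 1 `CC/C(=C(/c1ccc(/C=C/C(=O)O)cc1)c1ccc2nccn2c1)c1ccccc1`: 170 nM
- compound 2 `CC/C(=C(/c1ccc(/C=C/C(=O)O)cc1)c1ccc2cncn2c1)c1ccccc1`: > 500 nM (a limit of the assay, not a number)
- compound 3 `CC/C(=C(/c1ccc(/C=C/C(=O)O)cc1)c1ccc(-c2cncs2)cc1)c1ccccc1`: 31 nM

All three were tested in a functional assay on MCF7 cells (Homo sapiens) for antiproliferative activity, read by CellTiter-Glo, with a stated time of 5 days; on this read-out lower numbers stand for stronger inhibition and higher numbers for weaker inhibition. Compound 3, at 31 nM, holds the lower of the two actual numbers, and compound 1 sits higher at 170 nM.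

Compound 4 `CC/C(=C(/c1ccc(/C=C/C(=O)O)cc1)c1ccc(-c2cnn(C)c2)cc1)c1ccccc1` differs from compound 3 in one group: 1-methyl-1H-pyrazol-4-yl in place of 1,3-thiazol-5-yl on an aromatic carbon. The group sits para to a large group. Both the leaving and the entering group are five-membered aromatic rings with hetero atoms.

Going by the values given here, only one measured step offers any guide: an at least 2.9-fold higher number from compound 1 to compound 2 (0.46 log units; beyond the scatter). That swap lies elsewhere in the molecule, so it bears only loosely, but it shows that exchanging one aromatic group for a closely similar one can move the number beyond the scatter. No swap at this place has been measured.

Starting from compound 3 at 31 nM, the expected change is small: a 1.3-fold higher number from compound 3 to compound 4 (0.11 log units; within the scatter), not clearly beyond the scatter. For compound 4 the estimated value is 40 nM, with an expected range of 12 nM to 130 nM.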

Compound 4, half-maximal inhibitory concentration: 80 nM
The estimate for compound 4 lay 2.0-fold (0.30 log units) below the measured number, and the stated range covers the measured number.
By their numbers in this assay, from the lowest: compound 3; then compound 4; then compound 1. At a limit, above all of these: compound 2.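

In this assay, the place on the six-membered aromatic ring of carbon only, para to a large group, proves sensitive to which five-membered aromatic ring it carries: a 2.6-fold higher number from compound 3 to compound 4 (0.41 log units; beyond the scatter). The two groups have the same counts of hydrogen-bond donors and acceptors and no net charge, yet their numbers still differ beyond the scatter, so those counts alone do not predict the result at this place. The data shown offer no measured reason for this step.

As far as these compounds go, it remains open whether the methyl of the 1-methyl-1H-pyrazol-4-yl group contributes to the step, which a comparison with the unmethylated 1H-pyrazol-4-yl group could test. From the compounds shown here alone, it is also open how a group of another kind at this place, such as an amine, would compare with these two rings.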